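The source may report more compounds than this note shows. Statements on the series, on what has been measured and on what is new or still open speak of the compounds shown alone.

Compound 1 `CCCCC#Cc1cc([C@@H]2O[C@H](CO)[C@@H](O)[C@H]2O)n2ncnc(N)c12` is the anchor of this small set; in a functional assay on Z-138 cells (Homo sapiens) for antiproliferative activity, with a stated time of 72 h (a higher number here means a weaker inhibitor, a lower number a stronger inhibitor), compound 1 gives 200 nM, the low end of the three numbers seen. Compound 2 `Nc1ncnn2c([C@@H]3O[C@H](CO)[C@@H](O)[C@H]3O)cc(-c3ccc(Cl)cc3)c12` gives 40200 nM in this assay, and compound 3 `Nc1ncnn2c([C@@H]3O[C@H](CO)[C@@H](O)[C@H]3O)cc(-c3ccoc3)c12` gives 300 nM. Put as steps, a 200-fold higher number from compound 1 to compound 2 (2.30 log units; beyond the scatter), whereas a 1.5-fold higher number from compound 1 to compound 3 (0.18 log units; within the scatter), and a 130-fold lower number from compound 2 to compound 3 (2.13 log units; beyond the scatter). Compound 4 `Nc1ncnn2c([C@@H]3O[C@H](CO)[C@@H](O)[C@H]3O)cc(-c3ccsc3)c12` differs from compound 1 by thiophen-3-yl in place of hex-1-yn-1-yl on an aromatic carbon. The move to the furan-3-yl of compound 3, another five-membered aromatic ring with one hetero atom, changed little, while the 4-chlorophenyl of compound 2 changed much; thiophen-3-yl resembles the former. A small step, probably within the scatter and if anything toward a higher number, is therefore expected: a 1.8-fold higher number from compound 1 to compound 4 (0.24 log units; within the scatter). Compound 4 is estimated at 350 nM, with a range from 120 nM to 1200 nM.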

Compound 4, half-maximal inhibitory concentration: 43500 nM
Compound 4: the middle estimate sits 120-fold (2.09 log units) below what was measured, and the stated range ends below it.
By their numbers in this assay, from the lowest: compounds 1 and 3 (each within the scatter of the next); then compounds 2 and 4 (each within the scatter of the next).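

In this assay, two five-membered aromatic rings at this position part sharply, with sulfur in the ring of compound 4 and oxygen in that of compound 3 (a 150-fold higher number from compound 3 to compound 4 (2.16 log units; beyond the scatter)). Ring size alone therefore does not set the outcome here. Thiophen-3-yl also falls far from hex-1-yn-1-yl (a 220-fold higher number from compound 1 to compound 4 (2.34 log units; beyond the scatter)) and stays level with 4-chlorophenyl (a 1.1-fold higher number from compound 2 to compound 4 (0.03 log units; within the scatter)), leaving only compound 1 and compound 3 at the low numbers.

Nothing available here explains the gap between the furan-3-yl and thiophen-3-yl compounds. Going by these compounds, whether an amine or a longer chain such as oct-1-yn-1-yl would keep the low numbers remains open.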